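The source may hold more compounds than are shown below. What is called first, only, known or untested is meant among the compounds shown, and "the series" means these compounds.

Compound 2 `COc1ccc2c(c1)NC(=O)CN2c1nc(Nc2cccc(C#N)c2)nc2ccccc12` gives 384 nM in a functional assay on MCF7 cells (Homo sapiens) for inhibition, read by sulforhodamine B assay, with a stated time of 48 h (on this read-out lower numbers stand for stronger inhibition of growth and higher numbers for weaker inhibition of growth), which places it second highest among the three numbers measured. Compound 1 `COc1ccc2c(c1)NC(=O)CN2c1nc(COC(C)=O)nc2ccccc12` gives 33 nM, and the step of a 12-fold higher number from compound 1 to compound 2 (1.07 log units; beyond the scatter) is large. Compound 3 `COc1ccc2c(c1)NC(=O)CN2c1nc(COCCCC(=O)NO)nc2ccccc12` gives 1210 nM, and the step of a 3.2-fold higher number from compound 2 to compound 3 (0.50 log units; beyond the scatter) is modest, while the step of a 37-fold higher number from compound 1 to compound 3 (1.56 log units; beyond the scatter) is the largest seen. Compound 4 `CCCCNc1nc(N2CC(=O)Nc3cc(OC)ccc32)c2ccccc2n1` is not yet measured. It differs from compound 2 by butyl in place of 3-cyanophenyl on a nitrogen on an aromatic ring. Among the compounds with values here, none of the measured steps changes the group on that nitrogen: the steps from compound 1 to compound 2 and from compound 2 to compound 3 replace the whole group on the aromatic carbon, so they show only that this part of the shared core tolerates rather different groups with numbers spread over a wide range. The smallest group, acetoxymethyl on compound 1, gave the lowest number, and butyl is also a short group, so a number near that of compound 2 or somewhat lower is expected. For compound 4 the estimate is 300 nM, with a range from 80 nM to 1200 nM, which means an expected step of a 1.3-fold lower number from compound 2 to compound 4 (0.11 log units; within the scatter).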

Compound 4, concentration for 50% growth inhibition: 7.88 nM
Beside the measured number, compound 4's estimate is 38-fold (1.58 log units) above it; the measured number lies below the stated range.
By their numbers in this assay, from the lowest: compound 4; then compound 1; then compound 2; then compound 3.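

Butyl on this nitrogen gives the first measured change there, and in this assay the group proves to matter greatly: a 49-fold lower number from compound 2 to compound 4 (1.69 log units; beyond the scatter) shows that a low number here does not need the 3-cyanophenyl ring. Among the groups on the aromatic carbon of the shared core, butylamino gives the lowest number, with a 4.2-fold lower number from compound 1 to compound 4 (0.62 log units; beyond the scatter) against acetoxymethyl and a 150-fold lower number from compound 3 to compound 4 (2.19 log units; beyond the scatter) against (3-(hydroxycarbamoyl)propoxy)methyl, while compound 2 shows that having an amino nitrogen at that carbon is not enough on its own. Nothing measured here explains why replacing the ring with the chain has an effect of this size.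

From the compounds shown here alone, with butyl as the only chain on this nitrogen, it remains open whether ethyl, a longer chain such as hexyl, or a branched chain such as isobutyl would raise or lower the number. A plain phenyl group on the same nitrogen would help separate what the ring contributes to the step from what the nitrile contributes.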